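Dropping one chloro from compound 3: what to expect

This account rests on a few compounds, and the source may have more. Where it says the series, first, only, none or still open, it means among the compounds named here.

Of the compounds shown here, three sharing one core have been measured in a functional assay on the whole organism (Pleural cavity) for inhibition, with Rattus norvegicus as the target, at a dose of 25 mg/kg; on this read-out higher numbers stand for more inhibition at the one dose given (going by the name of the read-out) and lower numbers for less inhibition. Compound 1 `CC1(C)C(=O)N(c2ccc(S(C)(=O)=O)cc2)c2ncccc21` carries a methylsulfonyl group on its benzene ring and in this assay compound 1 gives 42%. Compound 2 `COc1ccc(N2C(=O)C(C)(C)c3cccnc32)cc1` carries a methoxy group instead, and in this assay compound 2 gives 63%; that single change is a number 21 percentage points higher from compound 1 to compound 2 (beyond the scatter). Compound 3 `CC1(C)C(=O)N(c2ccc(Cl)c(Cl)c2)c2ncccc21` carries two chloro groups, and in this assay compound 3 gives 26%, the lowest of the three numbers, standing beyond the scatter below both compound 1 and compound 2.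

Compound 4 `CC1(C)C(=O)N(c2cccc(Cl)c2)c2ncccc21` is reached from compound 3 by one change: hydrogen in place of chloro on an aromatic carbon. For the measured compounds named here, the only measured step swaps one group for another on the same ring and does not remove a chloro, so no step here bears directly on this change; the numbers for compound 1 and compound 3 merely show that different groups on that ring give different inhibition. With little to lean on, the expectation for compound 4 is a step of a number 9 percentage points higher from compound 3 to compound 4 (within the scatter), not clearly beyond the scatter. Compound 4 is therefore estimated at 35%, within 15% to 55%.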

Compound 4, a percentage reported as inhibition, in the whole organism at one dose (the size of the read-out at that dose, not a potency): 51%
For compound 4 the middle estimate is 16 percentage points below the measured one; the range from low to high includes it.
By their numbers in this assay, from the lowest: compound 3; then compounds 1 and 4 (each within the scatter of the next); then compound 2.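

Taking a single chloro off the benzene ring is enough to shift the read-out: in this assay the change gives a number 25 percentage points higher from compound 3 to compound 4 (beyond the scatter). Unlike the swap of methylsulfonyl for methoxy, this step removes a group and puts only a hydrogen in its place, so it tests this one position on its own. At this place, ortho to a chloro group and para to a large group, hydrogen goes with more inhibition at the one dose given than chloro does, while the other chloro stays the same in both compounds, and nothing measured here explains the size of this step.

Still open, from the compounds shown here alone, is how other groups at this same place would compare with hydrogen and chloro, for instance an amine or a carboxylic acid. Also open, going by these compounds, is what removing the remaining chloro of compound 4 would do, and whether a benzene ring carrying no group at all would read higher or lower than compound 4 in this assay.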